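The source may report more compounds than this note shows. Statements on the series, on what has been measured and on what is new or still open speak of the compounds shown alone.

Measured so far:
compound 1 `COc1ccc(F)cc1CNCCCNc1ccnc2cc(Cc3cc(C)cc(C)c3)ccc12` — 23 10^-6 cm/s
compound 2 `COc1ccc(F)cc1CNCCCNc1ccnc2cc(CC3CCCCC3)ccc12` — 23 10^-6 cm/s

In an ADME assay for permeability, using PAMPA, with a stated time of 30 min, at pH 7.4 (on this read-out higher numbers stand for higher permeability and lower numbers for lower permeability), compound 2 gives 23 10^-6 cm/s and stands level with compound 1 at the digits shown. Among the measured compounds shown here, the single measured step, no change at the digits printed from compound 1 to compound 2 (within the scatter), records no change beyond the scatter. Compound 3 `COc1ccc(F)cc1CNCCCNc1ccnc2cc(-c3cccc4ccccc34)ccc12` differs from compound 2 by naphthalen-1-yl in place of cyclohexylmethyl on an aromatic carbon. For the measured compounds named here, only this one step bears on the change; it involved the same position but a different pair of groups, so it is a loose guide. A step of about a 1.2-fold lower number from compound 2 to compound 3 (0.06 log units; within the scatter) in this assay is expected, none beyond the scatter. Compound 3 is therefore estimated at 20 10^-6 cm/s, range 10 10^-6 cm/s to 40 10^-6 cm/s.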

Compound 3, apparent permeability: 237 10^-6 cm/s
Compound 3: middle estimate off by 12-fold (1.07 log units), on the low side; the measured number lies above the stated range.
By their numbers in this assay, from the lowest: compounds 1 and 2 (each within the scatter of the next); then compound 3.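

In this assay, this aromatic carbon of the shared core proves far from indifferent to its group: naphthalen-1-yl in place of cyclohexylmethyl gives a 10-fold higher number from compound 2 to compound 3 (1.01 log units; beyond the scatter), and naphthalen-1-yl in place of 3,5-dimethylbenzyl gives a 10-fold higher number from compound 1 to compound 3 (1.01 log units; beyond the scatter). The exchange of 3,5-dimethylphenyl for cyclohexyl had given no sign of this, with no change at the digits printed from compound 1 to compound 2 (within the scatter). Nothing available accounts for the size of these steps.

Still open, from the compounds shown here alone, is whether the rise belongs to naphthalen-1-yl alone or would also follow a plain phenyl or naphthalen-2-yl on the same carbon.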